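Halogen swap on an N-hydroxypropyl nitroimidazole sulfone

This account rests on a few compounds, and the source may have more. Where it says the series, first, only, none or still open, it means among the compounds named here.

Measured compounds:
compound 1, `Cc1nc(CS(=O)(=O)c2ccc(Cl)cc2)c([N+](=O)[O-])n1C`, 68000 nM
compound 2, `Cc1nc(CS(=O)(=O)c2ccc(Br)cc2)c([N+](=O)[O-])n1C`, 326000 nM
compound 3, `Cc1nc(CS(=O)(=O)c2ccc(Cl)cc2)c([N+](=O)[O-])n1CC(C)O`, > 688000 nM (a limit)

Three compounds share a core and were tested in an ADME assay on THP-1 cells (Homo sapiens) for cytotoxicity, read by flow cytometry and propidium iodide staining, with a stated time of 72 h; a lower number here means a stronger inhibitor, a higher number a weaker inhibitor. Compound 1 gives 68000 nM. Compound 2 gives 326000 nM. Compound 3 gives > 688000 nM, which is a limit of the assay rather than a number. From compound 1 to compound 2 the change is bromo in place of chloro on an aromatic carbon, and it gave a 4.8-fold higher number from compound 1 to compound 2 (0.68 log units; beyond the scatter). From compound 1 to compound 3 the change is 1-hydroxyethyl in place of hydrogen on a saturated chain carbon bound to an aromatic nitrogen, which gave an at least 10-fold higher number from compound 1 to compound 3 (1.00 log units; beyond the scatter).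

Compound 4, `Cc1nc(CS(=O)(=O)c2ccc(Br)cc2)c([N+](=O)[O-])n1CC(C)O`, has not yet been measured in this assay . It differs from compound 3 by bromo in place of chloro on an aromatic carbon, the same change as that from compound 1 to compound 2, at the same place. In this assay the step from compound 3 to compound 4 is expected to be a step that the limit leaves unreadable from compound 3 to compound 4, resting on the step from compound 1 to compound 2 pointing the same way. Compound 4 is expected to give 1500000 nM, most likely reported only as a limit because compound 3 already sits at the limit of > 688000 nM in this assay, at which 1 of the 3 values shown sits.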

Compound 4, half-maximal inhibitory concentration: 126000 nM
Compound 4: the middle estimate sits 12-fold (1.08 log units) above what was measured; measured number below the stated range.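

In this assay, bromo in place of chloro gave an at least 5.4-fold lower number from compound 3 to compound 4 (0.73 log units; beyond the scatter), so on the core carrying the 1-hydroxyethyl group the change ran the opposite way to its course on the core of compound 1: the same change on two cores in this assay, a 4.8-fold higher number (0.68 log units; beyond the scatter) from compound 1 to compound 2 and an at least 5.4-fold lower number (0.73 log units; beyond the scatter) from compound 3 to compound 4, at least 26-fold (1.41 log units) apart, beyond the scatter of two such steps. The 1-hydroxyethyl change likewise failed to carry over, giving a 2.6-fold lower number from compound 2 to compound 4 (0.41 log units; beyond the scatter) on the bromo core, against a higher number on the chloro core: the same change on two cores in this assay, an at least 10-fold higher number (1.00 log units; beyond the scatter) from compound 1 to compound 3 and a 2.6-fold lower number (0.41 log units; beyond the scatter) from compound 2 to compound 4, at least 26-fold (1.41 log units) apart, beyond the scatter of two such steps. What this does not show is the exact size of the reversal or its cause: compound 3 gives > 688000 nM, a limit of the assay and not a number, so the direction of the two steps is clear but the distance between them is only bounded.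

The compounds shown leave open whether the reversal would hold for fluoro, iodo or a plain hydrogen in place of chloro and bromo. They also leave open how a longer chain or a carboxylic acid in place of the 1-hydroxyethyl group would behave with either halogen.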